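Sulfonamide chain extension from propyl to butyl

The source may report more compounds than this note shows. Statements on the series, on what has been measured and on what is new or still open speak of the compounds shown alone.

The three measured compounds share one core and differ only in the group on the sulfonamide nitrogen. Compound 1 `CCC1C(=O)N(C)c2cnc(Nc3ccc(S(=O)(=O)NCC(C)C)cc3)nc2N1c1ccn(C)n1` carries an isobutyl chain and gives 311 nM in an assay for inhibition of serine/threonine-protein kinase PLK2 (Homo sapiens), read by FRET and Z'-LYTE, with a stated time of 1 h; on this read-out lower numbers stand for stronger inhibition and higher numbers for weaker inhibition. Compound 2 `CCC1C(=O)N(C)c2cnc(Nc3ccc(S(=O)(=O)NCCO)cc3)nc2N1c1ccn(C)n1` carries a hydroxyethyl chain and gives 478 nM in this assay. Compound 3 `CCCNS(=O)(=O)c1ccc(Nc2ncc3c(n2)N(c2ccn(C)n2)C(CC)C(=O)N3C)cc1` carries a propyl chain and gives 190 nM in this assay. Going by the values given here, compound 3 has the lowest number of the three, but the step of a 1.6-fold lower number from compound 1 to compound 3 (0.21 log units; within the scatter) is within the scatter, so compound 1 and compound 3 cannot be ordered; only the step of a 2.5-fold lower number from compound 2 to compound 3 (0.40 log units; beyond the scatter) is beyond the scatter, and the step of a 1.5-fold higher number from compound 1 to compound 2 (0.19 log units; within the scatter) is within it.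

Compound 4 `CCCCNS(=O)(=O)c1ccc(Nc2ncc3c(n2)N(c2ccn(C)n2)C(CC)C(=O)N3C)cc1` differs from compound 3 by methyl in place of hydrogen on a saturated chain carbon, three bonds along the chain from a sulfonamide nitrogen. Among the compounds with values here, the closest precedent is the step of a 1.6-fold lower number from compound 1 to compound 3 (0.21 log units; within the scatter), which removed a methyl from the chain at a site two bonds from the sulfonamide nitrogen without a change beyond the scatter. The two steps that involve the hydroxy group do not bear on a plain chain extension. No step beyond the scatter is therefore expected in this assay for compound 4, and its estimated step from compound 3 is a 1.1-fold higher number from compound 3 to compound 4 (0.04 log units; within the scatter). Compound 4 is expected to give 210 nM, with a range of 100 nM to 450 nM.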

Compound 4, half-maximal inhibitory concentration: 191 nM
Estimate against measurement, compound 4: 1.1-fold (0.04 log units) above, and the stated range covers the measured number.
By their numbers in this assay, from the lowest: compounds 3, 4, 1 and 2 (each within the scatter of the next, the first and the last beyond it).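

Extending the chain from propyl to butyl, with methyl in place of hydrogen three bonds along the chain from a sulfonamide nitrogen, gives a 1.0-fold higher number from compound 3 to compound 4 (0.00 log units; within the scatter) in this assay and is the first straight extension read at this place, so the two chains cannot be told apart here. Straight and branched chains of the same carbon count also stay together, with propyl in place of isopropyl giving a 1.6-fold lower number from compound 1 to compound 4 (0.21 log units; within the scatter) and no order between the butyl and isobutyl compounds. Ethyl in place of hydroxy gives a 2.5-fold lower number from compound 2 to compound 4 (0.40 log units; beyond the scatter) and sits alongside a 2.5-fold lower number from compound 2 to compound 3 (0.40 log units; beyond the scatter) as a second modest step away from the hydroxyethyl compound, though compound 1 goes against a simple split between plain alkyl and hydroxy chains, since a 1.5-fold higher number from compound 1 to compound 2 (0.19 log units; within the scatter) stays within the scatter.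

From the compounds shown here alone, whether a longer chain such as pentyl, or an amine or a carboxylic acid at the chain end, would still leave the number close to those of the propyl and butyl compounds remains open. No measured property of these chains is available to account for any of these steps.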